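Indolyl imine series: swap at the ring nitrogen

The compounds below may be only part of what the source reports. "The series", "measured", "known", "first", "only" and "open" are said of these compounds alone.

Compound 1 `O=C1COCCN1c1ccc(/N=C\c2c[nH]c3ccccc23)cc1` gives 101% in an ADME assay on BV-2 cells (Mus musculus) for cytotoxicity, read by MTT assay, with a stated time of 48 h, tested at 5 uM; on this read-out lower numbers stand for a stronger effect and higher numbers for a weaker effect at the one concentration tested. Compound 2 `O=C1COCCN1c1ccc(/N=C\c2cn(C(=O)c3ccc(Cl)cc3)c3ccccc23)cc1` gives 93.7% in this assay, the lowest of the two numbers, yet only a number 7.3 percentage points lower from compound 1 to compound 2 (within the scatter) separates it from compound 1. Compound 3 `O=C1COCCN1c1ccc(/N=C\c2cn(Cc3ccccc3)c3ccccc23)cc1` carries the change (benzyl in place of (4-chlorophenyl)carbonyl on an aromatic nitrogen). For the measured compounds named here, the one measured step at this nitrogen, a number 7.3 percentage points lower from compound 1 to compound 2 (within the scatter), stayed within the scatter, so no step beyond the scatter is expected here either, in neither direction. Compound 3 is estimated at 97%, range 85% to 106%, an expected step of a number 3.3 percentage points higher from compound 2 to compound 3 (within the scatter).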

Compound 3, a percentage reported as activity, at one concentration (the size of the read-out at that concentration, not a potency): 84%
Compound 3: middle estimate off by 13 percentage points, on the high side, and the stated range ends above it.
By their numbers in this assay, from the lowest: compounds 3, 2 and 1 (each within the scatter of the next, the first and the last beyond it).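

For the compounds shown here, at the aromatic nitrogen, benzyl gives the first step beyond the scatter in this assay, modest in size (a number 17 percentage points lower from compound 1 to compound 3 (beyond the scatter)), so this position can move the read-out. Benzyl and (4-chlorophenyl)carbonyl remain within the scatter of each other (a number 9.7 percentage points lower from compound 2 to compound 3 (within the scatter)), so the compounds do not separate these two groups. No available evidence bears on the origin of the benzyl step. Open, going by these compounds, is whether an amine or a carboxylic acid on a longer chain at this nitrogen would give a larger step. Also open, on these data alone, is whether a simple methyl would retain the benzyl step.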